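Ethoxy for Methyl: Expecting Little Change in Cell Growth Inhibition

A few compounds are considered here, and "the series" means these few. Any claim that something is new, unique, unknown or untested is made for them only; others in the source may bear on it.

Going by the values given here, compound 2 `Cc1ccc2nc(C(=O)Nc3c(F)cc(-c4cccc(F)c4)cc3F)c(C)c(C(=O)O)c2c1` stands at the lower of the two numbers so far, yet within the scatter of its only neighbour: in a functional assay on A-375 cells (Homo sapiens) for antiproliferative activity, read by MTT assay, with a stated time of 24 h, tested at 0.14 ug/mL (on this read-out higher numbers stand for a stronger effect at the one concentration tested and lower numbers for a weaker effect), compound 2 gives 0.98%. Among the compounds with values here, that neighbour, compound 1 `Cc1ccc2nc(C(=O)Nc3c(F)cc(-c4cccc(F)c4)cc3F)c(C)c(O)c2c1`, gives 1.06%, and the single measured step, a number 0.1 percentage points lower from compound 1 to compound 2 (within the scatter), alters a different group from the one changed here. Compound 3 `CCOc1ccc2nc(C(=O)Nc3c(F)cc(-c4cccc(F)c4)cc3F)c(C)c(C(=O)O)c2c1` differs from compound 2 by ethoxy in place of methyl on an aromatic carbon. Within the data shown here, no measured step bears on this change, and both known values sit near zero, so no step beyond the scatter is expected; the estimated step is a number 1 percentage points higher from compound 2 to compound 3 (within the scatter). Compound 3 is therefore expected to give about 2%, ranging from -8% to 12%.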

Compound 3, a percentage reported as inhibition, at one concentration (the size of the read-out at that concentration, not a potency): 3.05%
Compound 3: middle estimate off by 1.1 percentage points, on the low side; measured number inside the range.
By their numbers in this assay, from the lowest: compounds 2, 1 and 3 (each within the scatter of the next).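

In this assay, ethoxy in place of methyl on this aromatic carbon gives a number 2.1 percentage points higher from compound 2 to compound 3 (within the scatter). Going by these compounds alone, this is the first look at this position, and it shows that a larger group carrying an oxygen can replace methyl here without a step beyond the scatter, although the numbers for both compounds remain small. Nothing measured here bears on what lies behind this result.

On these data alone, whether an amine, a chlorine atom or a longer chain such as butoxy at this position would give a step beyond the scatter remains open.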